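Replacing carboxy with 1H-tetrazol-5-yl

The source may hold more compounds than are shown below. What is called first, only, known or untested is meant among the compounds shown, and "the series" means these compounds.

In a functional assay on MDA-MB-231 cells (Homo sapiens) for cytotoxicity, read by MTT assay, with a stated time of 24 h (a lower number here means a stronger inhibitor, a higher number a weaker inhibitor), compound 2 `O=C(O)c1ccc(-c2nc3cccnc3n2C2CCCC2)cc1` gives 600 nM as the lower of the two exact numbers. Compound 1 `N#Cc1ccc(-c2nc3cccnc3n2C2CCCC2)cc1F` gives 2000 nM and so stands higher by more than the usual scatter. Compound 3 `c1cnc2c(c1)nc(-c1cncnc1)n2C1CCCC1` reports > 10000 nM as a limit of the assay, not a number. Compound 4 `c1cnc2c(c1)nc(-c1ccc(-c3nnn[nH]3)cc1)n2C1CCCC1` is still unmeasured. Its change from compound 2 is 1H-tetrazol-5-yl in place of carboxy on an aromatic carbon in full: 1H-tetrazol-5-yl in place of carboxy on an aromatic carbon. Within the data shown here, no measured pair shows this exchange, so the expectation starts from compound 2 at 600 nM and allows for a small move toward a weaker result. The expected step is a 1.7-fold higher number from compound 2 to compound 4 (0.22 log units; within the scatter) and may not exceed the scatter. The estimated value for compound 4 is 1000 nM and is expected to fall from 250 nM to 4000 nM when measured.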

Compound 4, half-maximal inhibitory concentration: 765 nM
Estimate against measurement, compound 4: 1.3-fold (0.12 log units) above; the range from low to high includes it.
By their numbers in this assay, from the lowest: compounds 2 and 4 (each within the scatter of the next); then compound 1. At a limit, above all of these: compound 3.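

In this assay, putting 1H-tetrazol-5-yl in place of carboxy, on the aromatic carbon para to a large group, gives a 1.3-fold higher number from compound 2 to compound 4 (0.11 log units; within the scatter). This place on the ring therefore accepts the larger five-membered aromatic ring in place of carboxy, with no difference beyond the scatter. No measured property shown here accounts for this match. Still open, from the compounds shown here alone, is how an amine or a methyl ester at this same place would read in this assay, and whether the two groups also match on another core.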